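A few compounds are considered here, and "the series" means these few. Any claim that something is new, unique, unknown or untested is made for them only; others in the source may bear on it.

Of the compounds shown here, three have so far been tested in an in vitro assay on SH-SY5Y cells for displacement of a labelled ligand from Neuronal acetylcholine receptor; alpha3/beta4 (Homo sapiens); a higher number here means a weaker inhibitor, a lower number a stronger inhibitor. Compound 3 `COc1cncc(C2=CC3CNCC(C2)C3)c1` gives 14.3 nM in this assay. Compound 2 `Clc1cncc(C2=CC3CNCC(C2)C3)c1` gives 40 nM in this assay. The two differ in a single place, (chloro in place of methoxy on an aromatic carbon), and that change brought a 2.8-fold higher number from compound 3 to compound 2 (0.45 log units; beyond the scatter). Compound 1 `COc1ccc(C2=CC3CC(C2)CN(C)C3)cn1` is known only to a limit: in this assay compound 1 gives > 10000 nM, which is a limit of the assay and not a number, as recorded in the limit of > 10000 nM in this assay, at which 1 of the 3 values shown sits. The difference between the core of compound 1 and the core of compound 3 is not broken down here.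

Compound 4 `CN1CC2C=C(c3ccc(Cl)nc3)CC(C2)C1` has not yet been measured in this assay. It differs from compound 1 by chloro in place of methoxy on an aromatic carbon. Among the compounds with values here, this is the same kind of change as the one separating compound 3 from compound 2, but not the same change: in the measured pair it sits two atoms from the ring nitrogen and meta to a group of 9 heavy atoms, whereas in compound 4 it sits next to the ring nitrogen and para to a large group.

Since compound 1 already shows only a limit, the expected step to compound 4 is a step that the limit leaves unreadable from compound 1 to compound 4, resting on the weakening seen in a 2.8-fold higher number from compound 3 to compound 2 (0.45 log units; beyond the scatter). Compound 4 is therefore expected to give about 30000 nM in this assay, most likely again only as a limit, with a plausible range from 10000 nM to 100000 nM.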

Compound 4, inhibition constant: 986 nM
Estimate against measurement, compound 4: 30-fold (1.48 log units) above; the measured number lies below the stated range.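

Replacing methoxy with chloro on the core of compound 4 gave an at least 10-fold lower number from compound 1 to compound 4 (1.00 log units; beyond the scatter) in this assay, the opposite direction to the earlier 2.8-fold higher number from compound 3 to compound 2 (0.45 log units; beyond the scatter). This shows that, among the compounds shown, the effect of this swap cannot simply be carried from one core to another, since neither its size nor its direction stayed the same: the same change on two cores in this assay, a 2.8-fold higher number (0.45 log units; beyond the scatter) from compound 3 to compound 2 and an at least 10-fold lower number (1.00 log units; beyond the scatter) from compound 1 to compound 4, at least 28-fold (1.45 log units) apart, beyond the scatter of two such steps

It does not show what lies behind the reversal, since the two pairs differ both in their core and in where the swap sits on the aromatic ring, and the true size of the new step stays unknown, since compound 1 is recorded only at a limit of the assay and not as a number: the limit of > 10000 nM in this assay, at which 1 of the 4 values shown sits.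

The compounds shown leave open whether the reversal follows the core or the place of the swap, a question that would need the same swap in both places on a single core. They also leave open how other groups, such as fluoro, a nitrile or an amine, would compare with chloro and methoxy in the place they hold in compound 4.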